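Tert-Butyl Replacing Iodo on the Chlorobutanamide Anilide

A few compounds are considered here, and "the series" means these few. Any claim that something is new, unique, unknown or untested is made for them only; others in the source may bear on it.

Compound 1 `CC(C)(C)c1ccc(NC(=O)CCl)cc1` gives 5400 nM in a functional assay on M21 cells (Homo sapiens) for antiproliferative activity, with a stated time of 48 h; a lower number here means a stronger inhibitor, a higher number a weaker inhibitor. Compound 2 `O=C(CCCCl)Nc1ccc(I)cc1` reaches only > 100000 nM in this assay, which is a limit of the assay and not a number. Compound 2 therefore sits at the limit of > 100000 nM in this assay, at which 1 of the 2 values shown sits. Compound 3 `CC(C)(C)c1ccc(NC(=O)CCCCl)cc1` carries tert-butyl in place of iodo on an aromatic carbon. For the measured compounds named here, no measured step covers this change; compound 1, also a tert-butyl anilide, does register a number, so a modest move toward measurable potency is expected rather than none. Compound 3 is expected to give 80000 nM, within 20000 nM to 300000 nM. The expected step is an at least 1.2-fold lower number from compound 2 to compound 3 (0.09 log units; that floor lies within the scatter).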

Compound 3, half-maximal inhibitory concentration: > 100000 nM
Compound 3: no number, only a limit (the forecaster's own chance of this, stated with the estimate: 55%); at least 1.2-fold (0.09 log units) between middle value and limit.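

Tert-butyl on the aromatic carbon does not by itself bring the longer chain into a measurable range in this assay: the limit of > 100000 nM in this assay, at which 2 of the 3 values shown sit.

The step between these two limits cannot be read, so iodo and tert-butyl stay unranked at this position. For the compounds shown here, with tert-butyl held fixed, 2-chloroethyl in place of chloro on the saturated chain carbon bound to the carbonyl carbon gives an at least 18-fold higher number from compound 1 to compound 3 (1.26 log units; beyond the scatter), the one readable change so far.

Still open, on these data alone, is whether iodo on the chain of compound 1 would give a number. Also open, as far as these compounds go, is whether bromo in place of the chain-end chloro would change the read-out.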